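A few compounds are considered here, and "the series" means these few. Any claim that something is new, unique, unknown or untested is made for them only; others in the source may bear on it.

Measured so far:
- compound 1 `C/C(=N\NC(=O)/C(C#N)=C/c1ccc(O)cc1)c1c(O)c2ccc(O)cc2oc1=O` with 61300 nM
- compound 2 `COc1ccc(/C=C(\C#N)C(=O)N/N=C(\C)c2c(O)c3ccc(O)cc3oc2=O)cc1OC` with 45300 nM
- compound 3 `C/C(=N\NC(=O)/C(C#N)=C/c1ccc(Br)cc1)c1c(O)c2ccc(O)cc2oc1=O` with 49600 nM

All three values come from a functional assay on NRK-49F cells (Rattus norvegicus) for cytotoxicity, read by MTT assay, with a stated time of 24 h (a lower number here means a stronger inhibitor, a higher number a weaker inhibitor), and cannot be told apart. Compound 3, at 49600 nM here, sits among the other two without separation, since a 1.2-fold lower number from compound 1 to compound 3 (0.09 log units; within the scatter) and a 1.1-fold higher number from compound 2 to compound 3 (0.04 log units; within the scatter) both stay within the scatter.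

Compound 4 `C/C(=N\NC(=O)/C(C#N)=C/c1cccc([N+](=O)[O-])c1)c1c(O)c2ccc(O)cc2oc1=O` follows from compound 3 by a single change 3-nitrophenyl in place of 4-bromophenyl on a double-bonded chain carbon bound to a double-bonded chain carbon in which 3-nitrophenyl takes the place of 4-bromophenyl on a double-bonded chain carbon bound to a double-bonded chain carbon.

The measured steps at this same place bear on it. Going to 3,4-dimethoxyphenyl from 4-hydroxyphenyl gave a 1.4-fold lower number from compound 1 to compound 2 (0.13 log units; within the scatter) and going to 4-bromophenyl from 3,4-dimethoxyphenyl gave a 1.1-fold higher number from compound 2 to compound 3 (0.04 log units; within the scatter) while the exchange of hydroxy for bromo gave a 1.2-fold lower number from compound 1 to compound 3 (0.09 log units; within the scatter) as well. Going by the values given here, none of the three left the scatter, though no compound with a nitro group has been measured, so the new group remains untested.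

In this assay no step beyond the scatter is therefore expected, in either direction. The estimate is a 1.0-fold higher number from compound 3 to compound 4 (0.00 log units; within the scatter) as the expected step. Estimated for compound 4 is 50000 nM with 27000 nM to 90000 nM as the expected range.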

Compound 4, half-maximal inhibitory concentration: 46500 nM
Compound 4: the middle estimate sits 1.1-fold (0.03 log units) above what was measured; the range from low to high includes it.
By their numbers in this assay, from the lowest: compounds 2, 4, 3 and 1 (each within the scatter of the next).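

In this assay, going by these compounds alone, a nitro group now appears for the first time on the phenyl ring at this place, and the exchange still gives only a 1.1-fold lower number from compound 3 to compound 4 (0.03 log units; within the scatter) against 4-bromophenyl, a 1.0-fold higher number from compound 2 to compound 4 (0.01 log units; within the scatter) against 3,4-dimethoxyphenyl and a 1.3-fold lower number from compound 1 to compound 4 (0.12 log units; within the scatter) against 4-hydroxyphenyl. The swap from 4-bromophenyl to 3-nitrophenyl adds heavy atoms and goes from 0 to 2 hydrogen-bond acceptors, yet it stays within the scatter, so all four phenyl groups on this double-bonded chain carbon now stand without separation and can be put in no order. Nothing available explains why these groups cannot be told apart.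

Every compound shown carries a phenyl ring at this place, so it remains open whether an amine or a carboxylic acid on that ring, or a longer chain in its stead, would move the number beyond the scatter. As far as these compounds go, the shared core and the nitrile are identical in all four compounds, so the effect of a change at either of them in this assay is also open.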